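The compounds below may be only part of what the source reports. "The series", "measured", "known", "first", "only" and "open" are said of these compounds alone.

Of the compounds shown here, two of a shared core have been measured in a functional assay on Caco-2 cells (Homo sapiens) for antiproliferative activity, read by MTT assay, with a stated time of 24 h; a lower number here means a stronger inhibitor, a higher number a weaker inhibitor. Compound 1 `c1ccc(C2=NN(c3ccc(-c4ccccc4)nn3)C(c3ccccc3)C2)cc1` carries an unsubstituted phenyl ring on the saturated carbon of the core; in this assay compound 1 gives 40900 nM. Compound 2 `Fc1ccc(C2CC(c3ccccc3)=NN2c2ccc(-c3ccccc3)nn2)cc1` carries a fluoro on that ring, and in this assay compound 2 gives 10000 nM. Among the compounds with values here, the single measured step, a 4.1-fold lower number from compound 1 to compound 2 (0.61 log units; beyond the scatter), runs from hydrogen to fluoro, so compound 2 stands as the lower of the two numbers, with compound 1 as its only neighbour.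

Compound 3 `COc1ccc(C2CC(c3ccccc3)=NN2c2ccc(-c3ccccc3)nn2)cc1` differs from compound 2 in one place: methoxy in place of fluoro on an aromatic carbon. Within the data shown here, no measured step swaps fluoro for methoxy, so the one step on record bears on this change only loosely, showing that a small group at this position can shift the number by a modest amount. Because that step, a 4.1-fold lower number from compound 1 to compound 2 (0.61 log units; beyond the scatter), was modest and the present change keeps a small group at the same position, a step of no change at the digits printed from compound 2 to compound 3 (within the scatter) is expected, which stays within the scatter. Compound 3 is therefore estimated at 10000 nM in this assay, with a range from 4000 nM to 30000 nM.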

Compound 3, half-maximal inhibitory concentration: > 100000 nM
Compound 3 ended at the assay's limit; the forecaster's own chance of this, stated with the estimate: 10%; middle value at least 10-fold (1.00 log units) from the limit.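

The value of compound 3 is a limit of the assay and not a number: the limit of > 100000 nM in this assay, at which 1 of the 3 values shown sits.

Even so, the change from 4-fluorophenyl to 4-methoxyphenyl gives an at least 10-fold higher number from compound 2 to compound 3 (1.00 log units; beyond the scatter), so two small groups on an aromatic carbon para to a large group are far from interchangeable in this assay. Compared with the plain phenyl ring, methoxy also moves the number in the opposite direction to fluoro, with an at least 2.4-fold higher number from compound 1 to compound 3 (0.38 log units; beyond the scatter), which means that a group at this place can either lower or raise the number, and the single earlier step showed only the lowering.

The true size of both new steps remains unknown, and these three compounds cannot say why fluoro and methoxy part ways so sharply. As far as these compounds go, it also remains open whether a chloro, a methyl or an amine at this place would follow fluoro towards a lower number or methoxy towards the limit, and a comparison of such groups would show which feature of methoxy matters here.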